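A few compounds are considered here, and "the series" means these few. Any claim that something is new, unique, unknown or untested is made for them only; others in the source may bear on it.

Series notes. Compound 1 `CC(C)Cc1ccc2c(NCCCNCc3ccco3)ccnc2c1` has been measured in a physicochemical assay for solubility, with a stated time of 18 h, at pH 7.4 (on this read-out lower numbers stand for lower solubility and higher numbers for higher solubility), where compound 1 gives 4200 nM. Compound 2 `COc1ccc(F)cc1CNCCCNc1ccnc2cc(CC(C)C)ccc12` gives 4200 nM and compound 3 `COc1ccc(F)cc1CNCCCNc1ccnc2cc(Cc3ccccc3)ccc12` gives 4200 nM, so compound 1 stands level with both at the digits shown. The only recorded moves in this assay are no change at the digits printed from compound 1 to compound 2 (within the scatter) and no change at the digits printed from compound 2 to compound 3 (within the scatter), both flat. Compound 4 `COc1cccc(Oc2ccc3c(NCCCNCc4ccco4)ccnc3c2)c1` differs from compound 1 by 3-methoxyphenoxy in place of isobutyl on an aromatic carbon. Neither recorded step swaps the whole group on that aromatic carbon; the closer of the two, from compound 2 to compound 3, alters only the saturated chain carbon bound to it and left the read-out unchanged. The expected step is therefore a 1.4-fold lower number from compound 1 to compound 4 (0.15 log units; within the scatter), a small downward move at most. Compound 4 is estimated at 3000 nM, with a range of 1000 nM to 9000 nM.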

Compound 4, solubility: 14500 nM
Estimate against measurement, compound 4: 4.8-fold (0.68 log units) below; measured number above the stated range.
By their numbers in this assay, from the lowest: compounds 1, 2 and 3 (each within the scatter of the next); then compound 4.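

In this assay, among the compounds shown here, 3-methoxyphenoxy in place of isobutyl on this aromatic carbon gives a 3.5-fold higher number from compound 1 to compound 4 (0.54 log units; beyond the scatter) and is the first step to leave the level shared by compounds 1, 2 and 3. Changing the whole group at this position therefore moves the read-out, whereas phenyl in place of isopropyl further out on the isobutyl group did not. Nothing at hand explains the step.

A single compound cannot separate the contributions of the ether oxygen, the aromatic ring and the methoxy group. Plain phenoxy or a methoxy group alone at this position would help separate them.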